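From Propargyl to 1-Carboxy-2-Methylbutyl on the Amide Nitrogen

The compounds below may be only part of what the source reports. "The series", "measured", "known", "first", "only" and "open" are said of these compounds alone.

In a functional assay on Caco-2 cells (Homo sapiens), read by MTT assay, with a stated time of 48 h (a higher number here means a weaker inhibitor, a lower number a stronger inhibitor), compound 2 `C#CCNC(=O)c1ccc(C(CC)(CC)c2ccc(OCC(O)C(C)(C)C)c(C)c2)n1CC` gives 39100 nM and stands level with compound 3 `CCn1c(C(=O)N(C)CC(=O)O)ccc1C(CC)(CC)c1ccc(OCC(=O)C(C)(C)C)c(C)c1` at 35900 nM within the scatter, while compound 1 `CCn1c(C(=O)NCCCN(C)C)ccc1C(CC)(CC)c1ccc(OCC(=O)C(C)(C)C)c(C)c1` shows a much lower number at 1400 nM by comparison. Compound 4 `CC[C@@H](C)[C@H](NC(=O)c1ccc(C(CC)(CC)c2ccc(OCC(O)C(C)(C)C)c(C)c2)n1CC)C(=O)O` has 1-carboxy-2-methylbutyl in place of propargyl on an amide-type nitrogen and awaits measurement. Within the data shown here, the one measured step that bears on this change is the large 26-fold higher number from compound 1 to compound 3 (1.41 log units; beyond the scatter) that introduced carboxymethyl. Compound 3 with that group gives 35900 nM in the same range as compound 2, so little movement is expected. The expected change is a 1.2-fold lower number from compound 2 to compound 4 (0.07 log units; within the scatter) in this assay and would stay within the scatter. Compound 4 is estimated at 33000 nM with an expected range from 14000 nM to 70000 nM overall.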

Compound 4, half-maximal inhibitory concentration: 3400 nM
For compound 4 the middle estimate is 9.7-fold (0.99 log units) above the measured one, outside the stated range (below it).
By their numbers in this assay, from the lowest: compound 1; then compound 4; then compounds 3 and 2 (each within the scatter of the next).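

In this assay, the amide-type nitrogen proves sensitive to what it carries: a 12-fold lower number from compound 2 to compound 4 (1.06 log units; beyond the scatter) accompanies 1-carboxy-2-methylbutyl replacing propargyl. The earlier carboxymethyl step, a 26-fold higher number from compound 1 to compound 3 (1.41 log units; beyond the scatter), ran the other way, so across these compounds a carboxyl-bearing group on this nitrogen sets no single direction. No measurement offered here accounts for the difference.

From the compounds shown here alone, whether the carboxylic acid or the branched carbon chain carries the step stays open. A methyl ester of this group, or a dialkylamine chain on the same nitrogen, would bear on that question.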